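Swapping methoxymethoxy for methyl on compound 3

The source may report more compounds than this note shows. Statements on the series, on what has been measured and on what is new or still open speak of the compounds shown alone.

In a functional assay on HL-60 cells (Homo sapiens) for cytotoxicity, read by WST assay, with a stated time of 48 h (on this read-out lower numbers stand for an effect already at smaller amounts and higher numbers for an effect only at larger amounts of compound), compound 1 `O=C1OC[C@H](Cc2ccccc2)[C@H]1Cc1ccccc1O` gives 83000 nM and compound 3 `COCOc1cccc(C[C@H]2C(=O)OC[C@@H]2Cc2ccccc2)c1` gives 80000 nM within the scatter of each other. Compound 2 `O=C1OC[C@H](Cc2ccccc2)[C@H]1Cc1cccc(O)c1` gives > 100000 nM as a limit of the assay. Compound 4 `Cc1cccc(C[C@H]2C(=O)OC[C@@H]2Cc2ccccc2)c1` carries methyl in place of methoxymethoxy on an aromatic carbon, meta to a large group (methyl in place of methoxymethoxy on an aromatic carbon). Among the measured compounds shown here, two measured steps bear on this change, and the step that adds methoxymethyl on the oxygen of compound 2 matters most. The steps of an at least 1.2-fold lower number from compound 2 to compound 3 (0.09 log units; that floor lies within the scatter) and an at least 1.2-fold higher number from compound 1 to compound 2 (0.08 log units; that floor lies within the scatter) both have floors within the scatter, so no step beyond the scatter is expected in this assay here. The expected step is no change at the digits printed from compound 3 to compound 4 (within the scatter) in size. Compound 4 is estimated at 80000 nM with an expected range from 40000 nM to 150000 nM overall.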

Compound 4, half-maximal effective concentration: 53000 nM
Compound 4: the middle estimate sits 1.5-fold (0.18 log units) above what was measured; the measured number falls inside the stated range.
By their numbers in this assay, from the lowest: compounds 4, 3 and 1 (each within the scatter of the next). At a limit, above all of these: compound 2.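

In this assay, methyl in place of methoxymethoxy gives a 1.5-fold lower number from compound 3 to compound 4 (0.18 log units; within the scatter), so this aromatic carbon tolerates a group with no oxygen and no hydrogen-bond acceptors. Likewise, 3-methylphenyl in place of 2-hydroxyphenyl gives a 1.6-fold lower number from compound 1 to compound 4 (0.19 log units; within the scatter). Compound 2 stands at a limit, so methyl in place of hydroxy gives only a floor, an at least 1.8-fold lower number from compound 2 to compound 4 (0.27 log units; that floor lies within the scatter): the limit of > 100000 nM in this assay, at which 1 of the 4 values shown sits.

As far as these compounds go, whether any group on this aromatic carbon can move the number beyond the scatter remains open. An amine or a carboxylic acid here would test that.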